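This account rests on a few compounds, and the source may have more. Where it says the series, first, only, none or still open, it means among the compounds named here.

In a functional assay on B16-F10 cells (Mus musculus) for antiproliferative activity, read by MTT assay, with a stated time of 48 h (on this read-out lower numbers stand for stronger inhibition and higher numbers for weaker inhibition), the measured compounds read as follows:

- compound 1 `COc1ccc(/C=C/c2cc(OC)cc(OC)c2/C=C/C(=O)c2cccc(OC)c2)cc1` gives 4.3 ug/mL
- compound 2 `COc1ccc(/C=C/c2cc(OC)cc(OC)c2/C=C/C(=O)c2ccc(C)cc2)cc1` gives 5.3 ug/mL
- compound 3 `COc1ccc(/C=C/c2cc(OC)cc(OC)c2/C=C/C(=O)c2ccc(C)c(C)c2)cc1` gives 1.4 ug/mL

Compound 3 holds the lowest number of the three. The shared core stays the same throughout, and only the group on the carbonyl carbon varies. Compound 4 `CCN(CC)c1ccc(C(=O)/C=C/c2c(/C=C/c3ccc(OC)cc3)cc(OC)cc2OC)cc1` continues that variation, and its change from compound 3 is 4-(diethylamino)phenyl in place of 3,4-dimethylphenyl on a carbonyl carbon.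

All three measured steps bear on this position. The step of a 1.2-fold higher number from compound 1 to compound 2 (0.09 log units; within the scatter) shows no real separation, while a 3.1-fold lower number from compound 1 to compound 3 (0.49 log units; beyond the scatter) and a 3.8-fold lower number from compound 2 to compound 3 (0.58 log units; beyond the scatter) are modest. The lowest number therefore belongs to the 3,4-dimethylphenyl compound alone, and compound 4 gives up that group. Among the compounds with values here, none of the measured compounds carries a 4-(diethylamino)phenyl group, so the data offer no direct precedent for it. The measured steps only suggest the likely scale of a change here.

A modest move toward weaker inhibition in this assay is therefore expected, roughly back toward the numbers of the other two compounds, and the expected step is a 2.5-fold higher number from compound 3 to compound 4 (0.40 log units; beyond the scatter). For compound 4 the estimated value is 3.5 ug/mL, with an expected range from 1.2 ug/mL to 10 ug/mL.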

Compound 4, half-maximal inhibitory concentration: 8.1 ug/mL
Beside the measured number, compound 4's estimate is 2.3-fold (0.36 log units) below it; the measured number falls inside the stated range.
By their numbers in this assay, from the lowest: compound 3; then compounds 1, 2 and 4 (each within the scatter of the next).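

In this assay the 4-(diethylamino)phenyl group on the carbonyl carbon does not keep what the 3,4-dimethylphenyl group gives, as shown by a 5.8-fold higher number from compound 3 to compound 4 (0.76 log units; beyond the scatter) on this change. Against the other two groups it shows no real separation, with a 1.5-fold higher number from compound 2 to compound 4 (0.18 log units; within the scatter) for diethylamino in place of methyl and a 1.9-fold higher number from compound 1 to compound 4 (0.28 log units; within the scatter) for the exchange with 3-methoxyphenyl, both of which stay within the scatter. Compound 3 therefore remains the strongest of the four, while three differently substituted phenyl groups, one of them the first here to bring a nitrogen to this place, read alike, and nothing available explains this outcome.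

Within the data shown here, what remains open is whether compound 3 marks a narrow result of its 3,4-dimethylphenyl group or the start of a trend, since only this one group reaches so low a number and no second compound tests it. Whether a smaller amine such as dimethylamino, a free carboxylic acid, or a longer alkyl chain in place of methyl would read with compound 3 or with the other three also stays unanswered by the compounds shown.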